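Ester in place of ether on the piperidine oxygen

The compounds below may be only part of what the source reports. "The series", "measured", "known", "first", "only" and "open" are said of these compounds alone.

Of the compounds shown here, three sharing one core have been tested in a functional assay on CHO-K1 cells for antagonist activity at transient receptor potential cation channel subfamily V member 1 (Homo sapiens), read by FLIPR; on this read-out higher numbers stand for weaker inhibition and lower numbers for stronger inhibition. Compound 1 `CC(C(=O)NCc1ccc(C(F)(F)F)nc1N1CCC(C(F)(F)F)CC1)c1ccc(NS(C)(=O)=O)c(F)c1` carries a trifluoromethyl on a saturated ring carbon and gives 0.6 nM. Compound 2 `COC1CCN(c2nc(C(F)(F)F)ccc2CNC(=O)C(C)c2ccc(NS(C)(=O)=O)c(F)c2)CC1` replaces that group with methoxy and gives 2.4 nM, a change of a 4.0-fold higher number from compound 1 to compound 2 (0.60 log units; beyond the scatter). Compound 3 `CC(C)OC1CCN(c2nc(C(F)(F)F)ccc2CNC(=O)C(C)c2ccc(NS(C)(=O)=O)c(F)c2)CC1` carries isopropoxy instead and gives 3 nM, a change of a 5.0-fold higher number from compound 1 to compound 3 (0.70 log units; beyond the scatter). Compound 3 has the highest number of the three, yet its gap to compound 2, a 1.3-fold higher number from compound 2 to compound 3 (0.10 log units; within the scatter), lies within the scatter; only its gap to compound 1 is beyond it.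

Compound 4 `CC(C(=O)NCc1ccc(C(F)(F)F)nc1N1CCC(OC(=O)C(C)(C)C)CC1)c1ccc(NS(C)(=O)=O)c(F)c1` differs from compound 3 by (tert-butyl)carbonyl in place of isopropyl on an oxygen on a saturated carbon. Within the data shown here, the only measured step that bears on this change is the one from methyl to isopropyl on that same oxygen, which moved the number by a 1.3-fold higher number from compound 2 to compound 3 (0.10 log units; within the scatter). Because that step stayed within the scatter, compound 4 is expected to change little, by a 1.7-fold higher number from compound 3 to compound 4 (0.22 log units; within the scatter). Compound 4 is therefore estimated at 5 nM, within a range of 1.5 nM to 15 nM.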

Compound 4, inhibition constant: 2 nM
Beside the measured number, compound 4's estimate is 2.5-fold (0.40 log units) above it, and the stated range covers the measured number.
By their numbers in this assay, from the lowest: compound 1; then compounds 4, 2 and 3 (each within the scatter of the next).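

Replacing the ether on this oxygen with an ester, which brings in a carbonyl and a larger group, leaves this assay within the scatter, with a 1.5-fold lower number from compound 3 to compound 4 (0.18 log units; within the scatter) and a 1.2-fold lower number from compound 2 to compound 4 (0.08 log units; within the scatter) as the two steps. Methyl, isopropyl and (tert-butyl)carbonyl on this oxygen therefore give numbers that cannot be told apart, while the separation from the trifluoromethyl of compound 1 remains, with a 3.3-fold higher number from compound 1 to compound 4 (0.52 log units; beyond the scatter) beyond the scatter, as it is for both ethers. Nothing measured here explains why this oxygen accepts such different groups with so little change in the number.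

The compounds shown leave open how an amine, a carboxylic acid or a longer chain on this saturated ring carbon would read. They also leave open whether any group on this oxygen can match compound 1 and its 0.6 nM result in this assay.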